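Furan in place of fluorophenyl on a cyano-pyrimidinone core

The compounds below may be only part of what the source reports. "The series", "measured", "known", "first", "only" and "open" are said of these compounds alone.

Measured compounds:
compound 1 `CCOC(=O)c1cnn(-c2nc(-c3ccccc3F)c(C#N)c(=O)n2C)c1N`, 86 ug/mL
compound 2 `CSc1nc(-c2cccs2)c(C#N)c(=O)n1C`, 72 ug/mL
compound 3 `CSc1nc(-c2ccccc2O)c(C#N)c(=O)n1C`, 39 ug/mL

In a functional assay, with a stated time of 10 min (a higher number here means a weaker inhibitor, a lower number a stronger inhibitor), compound 1 gives 86 ug/mL. Compound 2 gives 72 ug/mL, a value within the scatter of that of compound 1, so the two cannot be ordered. Going by the values given here, compound 3 gives 39 ug/mL, which lies beyond the scatter below compound 1; no single-point step connects these compounds, so only the two values themselves are known. Compound 4 `CCOC(=O)c1cnn(-c2nc(-c3ccco3)c(C#N)c(=O)n2C)c1N` is not yet measured; it differs from compound 1 by furan-2-yl in place of 2-fluorophenyl on an aromatic carbon. Compound 2 carries a five-membered heteroaryl on a different core and its value 72 ug/mL is close to compound 1, so compound 4 is expected to move no farther than the scatter. Compound 4 is estimated at 75 ug/mL, range 35 ug/mL to 160 ug/mL, a step of a 1.1-fold lower number from compound 1 to compound 4 (0.06 log units; within the scatter).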

Compound 4, half-maximal inhibitory concentration: 104 ug/mL
Compound 4: the middle estimate sits 1.4-fold (0.14 log units) below what was measured, within the range that was stated.
By their numbers in this assay, from the lowest: compounds 3, 2, 1 and 4 (each within the scatter of the next, the first and the last beyond it).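

In this assay the exchange of 2-fluorophenyl for furan-2-yl, on the aromatic carbon ortho to the cyano group, gives a 1.2-fold higher number from compound 1 to compound 4 (0.08 log units; within the scatter) and so stays within the scatter. With the rest of the molecule shared, this one place takes a five-membered aromatic ring with a hetero atom instead of a fluorinated six-membered ring without a step that can be told from the scatter. Nothing measured here explains this result. From the compounds shown here alone, whether an amine, a carboxylic acid or a longer alkyl chain on this carbon would move the number beyond the scatter stays open.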